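Extending a Side Chain on Compound 2

The compounds below may be only part of what the source reports. "The series", "measured", "known", "first", "only" and "open" are said of these compounds alone.

Two compounds sharing one core open this series in a functional assay on A2780 cells (Homo sapiens) for antiproliferative activity; a lower number here means a stronger inhibitor, a higher number a weaker inhibitor. For compound 1 `COC(=O)N1Cc2c(ccc(C)c2C)C(c2ccccc2)C1` the entry reads "not determined" (no result reported). Among the compounds with values here, that leaves compound 2 `Cc1ccc2c(c1C)CN(C(=O)N(C)C)CC2c1ccccc1`, at 1200 nM, with the only number available and no measured neighbour to be ranked against. Compound 3 `Cc1ccc2c(c1C)CN(C(=O)N(C)CCCN(C)C)CC2c1ccccc1` departs from compound 2 by one change: 2-(dimethylamino)ethyl in place of hydrogen on a saturated chain carbon bound to an amide-type nitrogen. Within the data shown here, no step between measured compounds exists to calibrate such a change, so the expectation is only a loose one. A moderate move towards stronger inhibition in this assay is expected, although a result within the usual scatter would be unsurprising. The expected size of the change is a 2.7-fold lower number from compound 2 to compound 3 (0.43 log units; beyond the scatter). Compound 3 is estimated at 450 nM, with an expected range of 90 nM to 2200 nM.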

Compound 3, half-maximal inhibitory concentration: 1210 nM
Beside the measured number, compound 3's estimate is 2.7-fold (0.43 log units) below it, and the stated range covers the measured number.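

Within the data shown here, compound 2 had no measured neighbour, and this pair gives the first reading at this position: in this assay the step is a 1.0-fold higher number from compound 2 to compound 3 (0.00 log units; within the scatter). Placing 2-(dimethylamino)ethyl in place of hydrogen on a saturated chain carbon bound to an amide-type nitrogen therefore leaves the two values indistinguishable, so the position accommodates this longer, amine-bearing chain with the antiproliferative read-out intact. Nothing available accounts for this result.

This single step cannot show whether the result extends to other groups at the position, such as a morpholine, a carboxylic acid or a still longer chain in place of the 2-(dimethylamino)ethyl group. It also leaves open whether any substituent here can move the number beyond the scatter in this assay.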